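Solubility of a piperidine amide: from hydroxy to methylcarbamoyl

This account rests on a few compounds, and the source may have more. Where it says the series, first, only, none or still open, it means among the compounds named here.

Measured compounds:
- compound 1, `NC(=O)CC1CCN(c2nc(-c3cc(F)c(Cl)cc3F)nc3c2CS(=O)(=O)C3)CC1`, 15000 nM
- compound 2, `NC(=O)C1CCN(c2nc(-c3cc(F)c(Cl)cc3F)nc3c2CS(=O)(=O)C3)CC1`, 40000 nM
- compound 3, `O=S1(=O)Cc2nc(-c3cc(F)c(Cl)cc3F)nc(N3CCC(O)CC3)c2C1`, 91000 nM

In a physicochemical assay for solubility, with a stated time of 20 h, at pH 6.8 (on this read-out higher numbers stand for higher solubility and lower numbers for lower solubility), compound 3 stands highest of the three measured compounds; the nearest is compound 2, which gives 40000 nM, and the furthest is compound 1, which gives 15000 nM. Compound 4, `CNC(=O)C1CCN(c2nc(-c3cc(F)c(Cl)cc3F)nc3c2CS(=O)(=O)C3)CC1`, differs from compound 3 by methylcarbamoyl in place of hydroxy on a saturated ring carbon. Among the measured compounds shown here, two measured steps bear on this change. The step of a 2.3-fold higher number from compound 2 to compound 3 (0.36 log units; beyond the scatter) shows what replacing a carbamoyl group by hydroxy at this ring carbon did, and the step of a 2.7-fold higher number from compound 1 to compound 2 (0.43 log units; beyond the scatter) shows that a carbamoyl group sitting one carbon further from the ring gave a lower number still. Compound 4 carries an amide again, now with a methyl on its nitrogen, so a step downward from compound 3 is expected, probably somewhat larger than the reverse of the hydroxy-for-carbamoyl step: a 3.0-fold lower number from compound 3 to compound 4 (0.48 log units; beyond the scatter). Compound 4 is therefore estimated at 30000 nM, with a likely range from 12000 nM to 70000 nM.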

Compound 4, solubility: 11000 nM
Compound 4: the middle estimate sits 2.7-fold (0.44 log units) above what was measured; the measured number lies below the stated range.
By their numbers in this assay, from the lowest: compounds 4 and 1 (each within the scatter of the next); then compound 2; then compound 3.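

In this assay the methyl on the amide nitrogen counts on its own: a 3.6-fold lower number from compound 2 to compound 4 (0.56 log units; beyond the scatter) shows that this small addition at the outer end of the group moves the number beyond the scatter. Measured against hydroxy, the full change is an 8.3-fold lower number from compound 3 to compound 4 (0.92 log units; beyond the scatter) and is the largest step among these four compounds, while a 1.4-fold lower number from compound 1 to compound 4 (0.13 log units; within the scatter) places methylcarbamoyl and carbamoylmethyl on this ring carbon within the scatter of each other. Nothing available here explains any of these steps.

Going by these compounds, it remains open how a second methyl or an ethyl group on the amide nitrogen would read, and whether a methyl on the amide nitrogen of compound 1 would give a similar step. An amine or a carboxylic acid on this ring carbon is also still an open question.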